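Larger benzyl group expected to sharpen orexin binding

A few compounds are considered here, and "the series" means these few. Any claim that something is new, unique, unknown or untested is made for them only; others in the source may bear on it.

Three measured compounds share one core and differ only in the group on a saturated chain carbon bound to an amide-type nitrogen in a ring. In an assay on HEK293 cells for displacement of a labelled ligand from Orexin receptor type 2 (Homo sapiens), read by scintillation counting, with a stated time of 90 min (on this read-out lower numbers stand for stronger inhibition and higher numbers for weaker inhibition), compound 1 `COc1cc(F)c(CN2C(=O)N(c3ccc(OC)c(OC)c3)S(=O)(=O)c3ccccc32)c(Cl)c1` gives 0.1 nM. In this assay compound 2 `COc1cc(F)c(CN2C(=O)N(c3ccc(OC)c(OC)c3)S(=O)(=O)c3ccccc32)c(F)c1` gives 0.501 nM, with a 5.0-fold higher number from compound 1 to compound 2 (0.70 log units; beyond the scatter). In this assay compound 3 `COc1ccc(N2C(=O)N(Cc3ccccc3F)c3ccccc3S2(=O)=O)cc1OC` gives 6.31 nM, the highest number of the three: the steps read a 63-fold higher number from compound 1 to compound 3 (1.80 log units; beyond the scatter) and a 13-fold higher number from compound 2 to compound 3 (1.10 log units; beyond the scatter), so compound 3 is the weakest binder shown.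

Compound 4 `COc1ccc(N2C(=O)N(Cc3c(F)cc(C)cc3Cl)c3ccccc3S2(=O)=O)cc1OC` differs from compound 3 by 2-chloro-6-fluoro-4-methylphenyl in place of 2-fluorophenyl on a saturated chain carbon bound to an amide-type nitrogen in a ring. The two steps into compound 3 both bear on this change, since each replaces a larger 2,6-disubstituted 4-methoxyphenyl with the plain 2-fluorophenyl and each costs a large amount. Compound 4 returns the chloro and fluoro pair and carries a methyl where compound 1 carries a methoxy, so a large drop in number is expected, though the size is uncertain. Compound 4 is therefore estimated at 0.2 nM in this assay, within 0.05 nM to 0.8 nM. This expectation corresponds to a 32-fold lower number from compound 3 to compound 4 (1.50 log units; beyond the scatter).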

Compound 4, inhibition constant: 0.794 nM
Compound 4: middle estimate off by 4.0-fold (0.60 log units), on the low side; measured number inside the range.
By their numbers in this assay, from the lowest: compound 1; then compounds 2 and 4 (each within the scatter of the next); then compound 3.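

Moving from the plain 2-fluorobenzyl group to 2-chloro-6-fluoro-4-methylbenzyl gives a 7.9-fold lower number from compound 3 to compound 4 (0.90 log units; beyond the scatter), so a gain at this position does not depend on having a methoxy group on the ring. Going by these compounds alone, the methoxy still counts when it is the only thing changed: methyl in its place gives a 7.9-fold higher number from compound 1 to compound 4 (0.90 log units; beyond the scatter), and this is the first step that isolates that one group. The step of a 1.6-fold higher number from compound 2 to compound 4 (0.20 log units; within the scatter) leaves those two compounds unranked, so the methyl compound with chloro and fluoro cannot be told apart from the methoxy compound with two fluoro groups.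

No measurement shown here explains these differences. Going by these compounds, it also remains open how an ethoxy group, a hydroxyl group or an amine would fare in the place of that methyl or methoxy.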